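Swapping One Methyl for Hydrogen on Compound 3

The source may hold more compounds than are shown below. What is called first, only, known or untested is meant among the compounds shown, and "the series" means these compounds.

Compound 1 `COc1ccc2c(c1)/C(=C/c1c(-c3ccncc3)nc3sccn13)C(=O)N2C` gives 68800 nM
Compound 2 `COc1nc2sc(C)cn2c1C=C1C(=O)N(C)c2ccccc21` gives 66700 nM
Compound 3 `COc1ccc2c(c1)/C(=C\c1c(OC)nc3sc(C)cn13)C(=O)N2` gives 52800 nM

In a functional assay on cells (Prostatic carcinoma cell, Homo sapiens) for cytotoxicity, read by sulforhodamine B assay, with a stated time of 48 h (on this read-out higher numbers stand for weaker inhibition of growth and lower numbers for stronger inhibition of growth), compound 3 gives 52800 nM and sits within the usual scatter of both other compounds. Compound 4 `COc1nc2sc(C)cn2c1/C=C1/C(=O)Nc2ccc(O)cc21` has not been measured yet. It differs from compound 3 in one place (hydrogen in place of methyl on an oxygen on an aromatic ring): hydrogen in place of methyl on an oxygen on an aromatic ring, or methoxy to hydroxy. Going by the values given here, no measured pair shows this change alone. Compound 1 (68800 nM) and compound 2 (66700 nM) differ from compound 3 in more than one place yet stay within the scatter of it, so no step beyond the scatter is expected. The expected step of a 1.1-fold lower number from compound 3 to compound 4 (0.02 log units; within the scatter) is therefore small. The estimate for compound 4 is 50000 nM (expected range 20000 nM to 100000 nM).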

Compound 4, concentration for total growth inhibition: 96200 nM
For compound 4 the middle estimate is 1.9-fold (0.28 log units) below the measured one; the range from low to high includes it.
By their numbers in this assay, from the lowest: compounds 3, 2, 1 and 4 (each within the scatter of the next).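

Going by these compounds alone, compounds 3 and 4 form the first measured pair that differs only at this spot, with hydrogen in place of methyl on an oxygen on an aromatic ring. In this assay this methoxy to hydroxy change gives a 1.8-fold higher number from compound 3 to compound 4 (0.26 log units; within the scatter), so at this position the swap stays inside the normal spread of repeat measurements. No available measurement offers a reason for this result.

Still open, on these data alone, is how an amine or a carboxylic acid would read in this place, and whether a longer chain on the same oxygen would give a step beyond the scatter.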